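Isopropyl to cyclobutyl on a carbonyl carbon

The source may hold more compounds than are shown below. What is called first, only, known or untested is meant among the compounds shown, and "the series" means these compounds.

Compound 1, `CCCCCC(=O)c1ccc(OCCCN2CCNCC2)cc1`, gives 14500 nM in an assay on isolated protein for binding affinity to histamine H2 receptor (Homo sapiens); a higher number here means a weaker inhibitor, a lower number a stronger inhibitor. Compound 2, `CCCCCC(=O)c1ccc(OCCCN2CCN(C(=O)OCC(C)C)CC2)cc1`, gives 3720 nM in this assay. Compound 3, `CCCCCC(=O)c1ccc(OCCCN2CCN(C(=O)C(C)C)CC2)cc1`, gives 29500 nM in this assay.

Compound 3 has the highest number of the three: a 2.0-fold higher number from compound 1 to compound 3 (0.31 log units; beyond the scatter), and a 7.9-fold higher number from compound 2 to compound 3 (0.90 log units; beyond the scatter). Compound 4, `CCCCCC(=O)c1ccc(OCCCN2CCN(C(=O)C3CCC3)CC2)cc1`, differs from compound 3 by a single change: cyclobutyl in place of isopropyl on a carbonyl carbon. Among the measured compounds shown here, no measured step swaps one small carbon group for another at this carbonyl carbon; the only step at that position, a 7.9-fold higher number from compound 2 to compound 3 (0.90 log units; beyond the scatter), exchanges a much less similar pair. The change is therefore expected to move the number little, if at all, beyond the scatter. For compound 4 the estimate is 25000 nM, within 10000 nM to 60000 nM, which would mean the expected step of a 1.2-fold lower number from compound 3 to compound 4 (0.07 log units; within the scatter).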

Compound 4, inhibition constant: 10200 nM
Beside the measured number, compound 4's estimate is 2.5-fold (0.39 log units) above it; the range from low to high includes it.
By their numbers in this assay, from the lowest: compound 2; then compounds 4 and 1 (each within the scatter of the next); then compound 3.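

This carbonyl carbon responds even when one small carbon group replaces another in this assay (a 2.9-fold lower number from compound 3 to compound 4 (0.46 log units; beyond the scatter)). Cyclobutyl still gives a higher number than isobutoxy at the same carbon (a 2.7-fold higher number from compound 2 to compound 4 (0.44 log units; beyond the scatter)), while cyclobutylcarbonyl in place of hydrogen on the amine nitrogen in a ring leaves the number within the scatter (a 1.4-fold lower number from compound 1 to compound 4 (0.15 log units; within the scatter)). No measurement here explains why cyclobutyl differs from isopropyl. From the compounds shown here alone, whether a cyclopropyl or cyclopentyl ring would lower the number further remains open. So does the outcome with a longer chain or an amine at this carbon.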